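A few compounds are considered here, and "the series" means these few. Any claim that something is new, unique, unknown or untested is made for them only; others in the source may bear on it.

Three compounds built on one shared core have been carried into an ADME assay on Vero cells (Chlorocebus sabaeus) for cytotoxicity, read by resazurin assay, with a stated time of 3 days (on this read-out lower numbers stand for stronger inhibition and higher numbers for weaker inhibition), and a fourth awaits its turn there. For compound 1 `CCCCCC(=O)Nc1cc2nc(C3CCCCC3)[nH]c2cc1N(CC)CC` the outcome is "not determined" (no result reported), so it contributes no figure. Compound 2 `CN(C)c1cc2[nH]c(C3CCCCC3)nc2cc1NC(=O)OCc1ccccc1` reaches only the ceiling of this assay, a limit rather than a number: in this assay compound 2 gives > 100 ug/mL. Compound 3 `CCCC(C)OC(=O)Nc1cc2nc(C3CCCCC3)[nH]c2cc1N(CC)CC` likewise stops at a limit and not a measured value, since in this assay compound 3 gives > 100 ug/mL. Compound 3 therefore stands at the limit of > 100 ug/mL in this assay, at which 2 of the 3 values shown sit, with no single number to set it against the others and no measured step between any two of these compounds to draw on. Compound 4 `CCN(CC)c1cc2[nH]c(C3CCCCC3)nc2cc1NC(=O)c1ccc(F)cc1F` differs from compound 3 in one place: 2,4-difluorophenyl in place of 1-methylbutoxy on a carbonyl carbon. With nothing measured to size this change, the step is expected to be a number no higher from compound 3 to compound 4 (the limit leaves the size open), none beyond the scatter. Compound 4 is therefore estimated at 100 ug/mL, within 25 ug/mL to 300 ug/mL, most likely again reported only as a limit.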

Compound 4, half-maximal inhibitory concentration: > 100 ug/mL
Compound 4: a limit, no number (the forecaster's own chance of this, stated with the estimate: 60%); the middle value lies on the limit itself.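

Among these compounds, compound 4 ends at a limit, as compound 3 does, so no step between compound 3 and compound 4 can be read: the limit of > 100 ug/mL in this assay, at which 3 of the 4 values shown sit. The compounds shown leave open what size of step, if any, 2,4-difluorophenyl in place of 1-methylbutoxy brings on a carbonyl carbon.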